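The compounds below may be only part of what the source reports. "The series", "measured", "known", "first", "only" and "open" are said of these compounds alone.

Compound 1 `CC(/C=N/Nc1ccc([N+](=O)[O-])cc1)=N\NC(=O)c1ccccc1Cl` gives in an ADME assay on J774 cells (Mus musculus, strain BALB/c) for cytotoxicity, read by resazurin assay, with a stated time of 72 h (a lower number here means that less compound is tolerated, a higher number that more compound is tolerated), a value that is a limit of the assay, > 100000 nM.
Compound 2 `CC(/C=N/Nc1ccc([N+](=O)[O-])cc1)=N\NC(=O)c1ccccc1N` gives in this assay 29800 nM.
Compound 3 `COc1ccc(C(=O)N/N=C(C)/C=N/Nc2ccc([N+](=O)[O-])cc2)cc1` gives in this assay a value that is again a limit, > 100000 nM.

Compound 3 therefore stands at the upper edge of what the numbers can show; two of the three values sit at the limit of > 100000 nM in this assay, at which 2 of the 3 values shown sit. Compound 4 `CC(/C=N/Nc1ccc([N+](=O)[O-])cc1)=N\NC(=O)c1ccc(N(C)C)cc1` carries dimethylamino in place of methoxy on an aromatic carbon. Going by the values given here, no measured step exchanges these two groups. The steps that touch the carbonyl-bound ring are an at least 3.3-fold higher number from compound 2 to compound 3 (0.52 log units; beyond the scatter) and an at least 3.3-fold lower number from compound 1 to compound 2 (0.52 log units; beyond the scatter), and a step that the two limits leave unreadable from compound 1 to compound 3. Only the amino-bearing compound 2 falls clearly below the limit, so compound 4 is expected to stay close to compound 3, with an at least 1.4-fold lower number from compound 3 to compound 4 (0.15 log units; that floor lies within the scatter). The estimate for compound 4 is 70000 nM, ranging from 20000 nM to 150000 nM.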

Compound 4, half-maximal cytotoxic concentration: > 100000 nM
Compound 4 ended at the assay's limit; the forecaster's own chance of this, stated with the estimate: 50%; middle value at least 1.4-fold (0.15 log units) from the limit.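

In this assay compound 4, with dimethylamino on this aromatic carbon, gives > 100000 nM, which is a limit of the assay. Going from 2-aminophenyl to 4-(dimethylamino)phenyl gives an at least 3.3-fold higher number from compound 2 to compound 4 (0.52 log units; beyond the scatter), so a nitrogen group on this ring does not in itself bring the value under the limit. The steps from compound 1 and from compound 3 to compound 4 cannot be read, and the values now gather at one edge: the limit of > 100000 nM in this assay, at which 3 of the 4 values shown sit.

As far as these compounds go, whether dimethylamino and methoxy differ at all in this assay stays open. Also open, from the compounds shown here alone, is what a plain amine, a carboxylic acid or a longer chain would do at this position.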